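A few compounds are considered here, and "the series" means these few. Any claim that something is new, unique, unknown or untested is made for them only; others in the source may bear on it.

Compound 2 `CC(=O)NC1CCN(c2ccc3cc(NC(=O)CCc4ccc(C(F)(F)F)cc4)ccc3n2)C1` stands highest of the two single numbers seen so far in a functional assay on HEK293 cells for activation of melanin-concentrating hormone receptor 1 (Rattus norvegicus), read by inositol phosphate accumulation (on this read-out lower numbers stand for an effect already at smaller amounts and higher numbers for an effect only at larger amounts of compound), where compound 2 gives 440 nM. Its nearest neighbour is compound 1 `O=C(CCc1ccc(C(F)(F)F)cc1)Nc1ccc2nc(N3CC4CCC3C4)ccc2c1`, which in this assay gives 150 nM, and the step of a 2.9-fold higher number from compound 1 to compound 2 (0.47 log units; beyond the scatter) shows that putting the 3-acetamidopyrrolidin-1-yl group in place of the group of compound 1 raised the number. Compound 3 `O=C(CCc1ccc(C(F)(F)F)cc1)Nc1ccc2nc(N3CCCC3)ccc2c1` gives 320 nM; 320 nM (2 entries) in this assay. Compound 4 `CC1CCCN1c1ccc2cc(NC(=O)CCc3ccc(C(F)(F)F)cc3)ccc2n1` differs from compound 2 by 2-methylpyrrolidin-1-yl in place of 3-acetamidopyrrolidin-1-yl on an aromatic carbon. Among the measured compounds shown here, the one step that bears on this, a 2.9-fold higher number from compound 1 to compound 2 (0.47 log units; beyond the scatter), suggests that taking the acetamido group away again should bring a lower number, and compound 3 with its 320 nM; 320 nM (2 entries) points the same way. Compound 4 is therefore expected to show a 1.8-fold lower number from compound 2 to compound 4 (0.25 log units; within the scatter), an estimate of 250 nM with a range from 100 nM to 600 nM.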

Compound 4, half-maximal effective concentration: 270 nM
The estimate for compound 4 lay 1.1-fold (0.03 log units) below the measured number; the measured number falls inside the stated range.
By their numbers in this assay, from the lowest: compounds 1, 4 and 2 (each within the scatter of the next, the first and the last beyond it).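

In this assay, the step of a 1.6-fold lower number from compound 2 to compound 4 (0.21 log units; within the scatter) and the step of a 1.8-fold higher number from compound 1 to compound 4 (0.26 log units; within the scatter) both stay within the usual scatter, so compound 4 cannot be told apart from either neighbour, even though compound 1 and compound 2 differ beyond it. On this aromatic carbon next to the ring nitrogen, 2-methylpyrrolidin-1-yl therefore sits in the span already set by the two other groups. Nothing measured here explains these numbers. Still open, as far as these compounds go, is whether a piperidin-1-yl or morpholin-4-yl group at this place, or a carboxylic acid on the pyrrolidine ring, would move the number beyond the scatter.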